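From sec-butyl to hexyl on an amide-type nitrogen

A few compounds are considered here, and "the series" means these few. Any claim that something is new, unique, unknown or untested is made for them only; others in the source may bear on it.

In a functional assay on MCF7 cells (Homo sapiens) for inhibition, read by MTT assay, with a stated time of 48 h (on this read-out lower numbers stand for stronger inhibition and higher numbers for weaker inhibition), compound 1 `COc1ccc(/C=C/c2cc(OC)cc(OC)c2/C=C/C(=O)NC2CC2)cc1` gives 3940 nM, compound 2 `COc1ccc(/C=C/c2cc(OC)cc(OC)c2/C=C/C(=O)N2CCC(Cl)CC2)cc1` gives 4950 nM and compound 3 `CCC(C)NC(=O)/C=C/c1c(/C=C/c2ccc(OC)cc2)cc(OC)cc1OC` gives 3430 nM. Compound 3 thus stands within the scatter of both neighbours. Compound 4 `CCCCCCNC(=O)/C=C/c1c(/C=C/c2ccc(OC)cc2)cc(OC)cc1OC` has hexyl in place of sec-butyl on an amide-type nitrogen. The closest evidence is sec-butyl replacing cyclopropyl at that nitrogen, a 1.1-fold lower number from compound 1 to compound 3 (0.06 log units; within the scatter). The two other changes of this amide group, a 1.3-fold higher number from compound 1 to compound 2 (0.10 log units; within the scatter) and a 1.4-fold lower number from compound 2 to compound 3 (0.16 log units; within the scatter), were equally small. Among the measured compounds shown here, no hexyl compound has been measured, so this evidence is indirect. The expected change stays within the scatter, with no clear direction: a 1.1-fold higher number from compound 3 to compound 4 (0.03 log units; within the scatter). The estimate for compound 4 is 3700 nM, with an expected range from 1800 nM to 7500 nM.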

Compound 4, half-maximal inhibitory concentration: 5530 nM
Beside the measured number, compound 4's estimate is 1.5-fold (0.17 log units) below it; measured number inside the range.
By their numbers in this assay, from the lowest: compounds 3, 1, 2 and 4 (each within the scatter of the next).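

Hexyl, the longest chain on this amide-type nitrogen so far, stays within the scatter of all three earlier amides (a 1.6-fold higher number from compound 3 to compound 4 (0.21 log units; within the scatter)), (a 1.4-fold higher number from compound 1 to compound 4 (0.15 log units; within the scatter)) and (a 1.1-fold higher number from compound 2 to compound 4 (0.05 log units; within the scatter)). Cyclopropyl, sec-butyl, hexyl and the 4-chloropiperidin-1-yl amide therefore remain unseparated in this assay, despite their different shapes and sizes. No measurement shown here offers an explanation for these small steps. Still open, from the compounds shown here alone, is whether a longer chain such as decyl would give a step beyond the scatter. An amine or a carboxylic acid at the end of the hexyl chain also remains untested among the compounds shown.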